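The source may hold more compounds than are shown below. What is called first, only, known or untested is meant among the compounds shown, and "the series" means these compounds.

Of the compounds shown here, three that share one core have been measured in a functional assay on HEK293 cells with D(4) dopamine receptor (Homo sapiens) as the target, read by FLIPR; a lower number here means that less compound is needed, a higher number that more compound is needed for the effect. Compound 1 `O/N=C(\CCN1CCN(c2ccccn2)CC1)c1ccccc1` gives 4.4 nM, which places it second highest of the three numbers. Compound 2 `Cc1ccccc1/C(CCN1CCN(c2ccccn2)CC1)=N/O` gives 4.2 nM, and the step of a 1.0-fold lower number from compound 1 to compound 2 (0.02 log units; within the scatter) lies within the scatter, so the two are indistinguishable here. Compound 3 `O/N=C(\CCN1CCN(c2ccccn2)CC1)c1ccc(Cl)cc1` gives 475 nM; the step of a 110-fold higher number from compound 1 to compound 3 (2.03 log units; beyond the scatter) is large and beyond the scatter.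

Compound 4 `CC(C)O/N=C(\CCN1CCN(c2ccccn2)CC1)c1ccccc1` is not yet measured. It differs from compound 1 by isopropyl in place of hydrogen on an oxygen. Going by the values given here, all measured steps alter the aromatic ring, none the oxygen, so no step bears directly on this change; the only guide is that the core tolerates a methyl in a 1.0-fold lower number from compound 1 to compound 2 (0.02 log units; within the scatter) while the chloro in a 110-fold higher number from compound 1 to compound 3 (2.03 log units; beyond the scatter) is costly. A moderate rise in this assay is therefore expected, giving an estimated step of a 3.4-fold higher number from compound 1 to compound 4 (0.53 log units; beyond the scatter) for compound 4. Compound 4 is estimated at 15 nM, with a likely range from 4 nM to 60 nM.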

Compound 4, half-maximal effective concentration: 164 nM
For compound 4 the middle estimate is 11-fold (1.04 log units) below the measured one; the measured number lies above the stated range.
By their numbers in this assay, from the lowest: compounds 2 and 1 (each within the scatter of the next); then compound 4; then compound 3.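

Going by these compounds alone, the change from hydroxy to isopropoxy is the first one at this oxygen, and in this assay it gives a 37-fold higher number from compound 1 to compound 4 (1.57 log units; beyond the scatter), a large step. Within the data shown here, the earlier compounds showed only that the number can respond strongly to a change on the aromatic ring, as with the chloro group; this result shows that the oxygen is a second place where a single change can raise it far beyond the scatter. Nothing measured here accounts for the size of this step.

With isopropyl as the only group shown on this oxygen, it remains open whether a methyl would carry a similar cost or whether the cost grows from methyl through ethyl to isopropyl. As far as these compounds go, it also remains open how a longer chain ending in an amine or a carboxylic acid would fare at this position.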